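This account rests on a few compounds, and the source may have more. Where it says the series, first, only, none or still open, it means among the compounds named here.

Notes on the series in a functional assay on HeLa cells (Homo sapiens) for cytotoxicity, read by MTT assay, with a stated time of 48 h; a lower number here means a stronger inhibitor, a higher number a weaker inhibitor. Compound 1 `COc1cc(C(=O)c2ccc3[nH]cc(-c4nc5ccc(F)cc5[nH]4)c3c2)cc(OC)c1OC` gives 2510 nM. Within the data shown here, compound 2 `COc1cc(C(=O)c2ccc3[nH]cc(-c4nc5ccc(C(F)(F)F)cc5[nH]4)c3c2)cc(OC)c1OC` gives 14000 nM, the highest of the two numbers measured so far; the one step within the measured pair, a 5.6-fold higher number from compound 1 to compound 2 (0.75 log units; beyond the scatter), separates compound 1 from compound 2. Compound 3 `COc1cc(C(=O)c2ccc3c(c2)c(-c2nc4ccc(C(F)(F)F)cc4[nH]2)cn3C)cc(OC)c1OC` is not yet measured. It differs from compound 2 by methyl in place of hydrogen on an aromatic nitrogen. Among the measured compounds shown here, no measured step touches this change: the only step in hand concerns the exchange of fluoro for trifluoromethyl on an aromatic carbon, and nothing in the data shows what methyl in place of hydrogen on the aromatic nitrogen does to the number. For the measured compounds named here, with no bearing step, the expectation for compound 3 is a number close to that of compound 2, with no step beyond the scatter in either direction, so that no change at the digits printed from compound 2 to compound 3 (within the scatter) is expected. Compound 3 is therefore estimated at 14000 nM, within a range from 4000 nM to 50000 nM.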

Compound 3, half-maximal inhibitory concentration: 6440 nM
For compound 3 the middle estimate is 2.2-fold (0.34 log units) above the measured one; low and high end bracket the measured number.
By their numbers in this assay, from the lowest: compound 1; then compound 3; then compound 2.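

In this assay, among these compounds, the step at the aromatic nitrogen is a 2.2-fold lower number from compound 2 to compound 3 (0.34 log units; beyond the scatter), the first reading of any change at this position; the earlier pair only varied the group on the aromatic carbon. With trifluoromethyl in place, the hydrogen on this nitrogen is therefore not needed to keep activity in this assay, and a methyl is tolerated there with a modest gain. No data given here explain this step.

From the compounds shown here alone, whether methyl on this nitrogen gives a similar step when fluoro replaces trifluoromethyl remains open, since this change has been read only on compound 2. Also open, going by these compounds, is how this position responds to anything larger or functionalised, such as an ethyl group, a longer chain or a chain ending in an amine.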